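Removing a trifluoromethyl group from a pyrazole urea

The compounds below may be only part of what the source reports. "The series", "measured", "known", "first", "only" and "open" are said of these compounds alone.

Measured compounds:
compound 1 `O=C(Nc1cccc(-n2cc(-c3ccncc3)c(-c3cc(O)cc(Cl)c3)n2)c1)Nc1ccc(Cl)c(C(F)(F)F)c1` gives 93% in a functional assay on NCI-H322M cells (Homo sapiens) for inhibition, read by sulforhodamine B assay, with a stated time of 48 h, tested at 1 uM; a lower number here means a stronger effect, a higher number a weaker effect of the compound at the concentration tested
compound 2 `O=C(Nc1cccc(-n2cc(-c3ccncc3)c(-c3cc(O)cc(Cl)c3)n2)c1)Nc1ccc(Cl)c(Cl)c1` gives 59%
compound 3 `COc1cc(Cl)cc(-c2nn(-c3cccc(NC(=O)Nc4cc(C(F)(F)F)cc(C(F)(F)F)c4)c3)cc2-c2ccncc2)c1` gives 49%

Among these three numbers compound 3 carries the lowest one, yet its gap to compound 2 lies within the scatter, so the two cannot be ranked; only the gap to compound 1 lies beyond the scatter. Among the compounds with values here, the single change measured here is the one from compound 1 to compound 2, where a number 34 percentage points lower from compound 1 to compound 2 (beyond the scatter) follows the exchange of chloro for trifluoromethyl on an aromatic carbon.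

Compound 4 `COc1cc(Cl)cc(-c2nn(-c3cccc(NC(=O)Nc4cccc(C(F)(F)F)c4)c3)cc2-c2ccncc2)c1` has not been measured. It differs from compound 3 in one place: hydrogen in place of trifluoromethyl on an aromatic carbon.

Within the data shown here, no measured pair exchanges a trifluoromethyl group for a hydrogen atom, so the step from compound 1 to compound 2 bears on it only loosely, showing that a single change at this ring can move the read-out by a large amount. Taking away a group rather than exchanging it is expected, on balance, to leave less effect, so a rise of a number 17 percentage points higher from compound 3 to compound 4 (beyond the scatter) is expected, possibly beyond the scatter. Compound 4 is therefore estimated at 66%, with a range from 45% to 90%.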

Compound 4, a percentage reported as activity, at one concentration (the size of the read-out at that concentration, not a potency): 83%
Beside the measured number, compound 4's estimate is 17 percentage points below it; low and high end bracket the measured number.
By their numbers in this assay, from the lowest: compounds 3 and 2 (each within the scatter of the next); then compounds 4 and 1 (each within the scatter of the next).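

In this assay, taking the trifluoromethyl group away from the carbon meta to the other trifluoromethyl group, with only hydrogen entering, gives a number 34 percentage points higher from compound 3 to compound 4 (beyond the scatter), so in this pair the effect at the concentration tested depends heavily on that group. The earlier step, a number 34 percentage points lower from compound 1 to compound 2 (beyond the scatter), also removed a trifluoromethyl group, but chloro took its place and the number fell, whereas here the number rises; the loss of a trifluoromethyl group therefore has no single direction across these two pairs, which differ in the group that enters, in the other substituents on the ring and in the rest of the core. No measurement given here bears on why the read-out moves in either pair.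

From the compounds shown here alone, it remains open whether a smaller group such as methyl, or an amine or a carboxylic acid, on this same carbon would keep the read-out near that of compound 3 or leave it near that of compound 4. Going by these compounds, it is also open whether hydrogen in place of trifluoromethyl would give a step of similar size on the core of compound 1, which carries a hydroxy group where compound 3 carries a methoxy group.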